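The compounds below may be only part of what the source reports. "The series", "measured", "known", "first", "only" and "open" are said of these compounds alone.

Measured so far:
- compound 1, `CC(C)CSc1nc(N)nc2c1ncn2/C=C1/CC1(CO)CO`: > 20000 nM
- compound 2, `Nc1nc(NCc2ccccc2)c2ncn(/C=C3/CC3(CO)CO)c2n1`: 19900 nM

In an ADME assay on BCBL1 cells (Homo sapiens) for cytotoxicity, with a stated time of 7 days (a lower number here means that less compound is tolerated, a higher number that more compound is tolerated), compound 1 reaches only a limit of the assay, > 20000 nM, not a number. Compound 2 gives 19900 nM in this assay. Among the measured compounds shown here, the one measured step, a number no higher from compound 1 to compound 2 (the limit leaves the size open), swaps the whole group on the aromatic carbon; its size cannot be read because one of its two values is the limit (the limit of > 20000 nM in this assay, at which 1 of the 2 values shown sits). Compound 3, `CCCCCCCCSc1nc(N)nc2c1ncn2/C=C1/CC1(CO)CO`, differs from compound 1 at another place: heptyl in place of isopropyl on a saturated chain carbon bound to a sulfur. For the measured compounds named here, no measured step touches this chain, and the only step on record has no readable size, so it gives no direction for compound 3. Compound 3 is therefore expected to sit near where compound 1 does, with the estimate 15000 nM spanning 5000 nM to 30000 nM. That estimate means a step of an at least 1.3-fold lower number from compound 1 to compound 3 (0.12 log units; that floor lies within the scatter) expected to lie within the scatter, with a fair chance that only a limit is reported.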

Compound 3, half-maximal cytotoxic concentration: > 20000 nM
Compound 3 ended at the assay's limit; the forecaster's own chance of this, stated with the estimate: 50%; middle value at least 1.3-fold (0.12 log units) from the limit.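

In this assay compound 3 gives > 20000 nM, which is a limit of the assay and not a number. Octylsulfanyl in place of benzylamino on an aromatic carbon gives a number no lower from compound 2 to compound 3 (the limit leaves the size open). Going from isobutylsulfanyl to octylsulfanyl therefore does not bring a measurable number into view: compound 1 and compound 3 both stop at a limit. Neither new step has a readable size because of where these values sit: the limit of > 20000 nM in this assay, at which 2 of the 3 values shown sit.

The compounds shown leave open how far past that limit compound 1 and compound 3 lie, and so whether heptyl in place of isopropyl changes the tolerated concentration at all. They also leave open how a chain carrying an amine or a carboxylic acid would behave in this assay.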